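One inverted stereocentre in a series at the limit

The source may report more compounds than this note shows. Statements on the series, on what has been measured and on what is new or still open speak of the compounds shown alone.

compound 1 `Nc1ccn([C@H]2CC(F)(F)[C@H](CO)O2)c(=O)n1`: > 100000 nM
compound 2 `Cc1cn([C@H]2CC(F)(F)[C@H](CO)O2)c(=O)[nH]c1=O`: > 100000 nM
compound 3 `Cc1cn([C@@H]2C=C(F)[C@H](CO)O2)c(=O)nc1O`: > 100000 nM

All three entries come from a functional assay on CCRF-CEM cells (Homo sapiens) for cytotoxicity (on this read-out higher numbers stand for weaker inhibition and lower numbers for stronger inhibition), and each is a limit of the assay rather than a number. Going by the values given here, the whole series so far amounts to the limit of > 100000 nM in this assay, at which 3 of the 3 values shown sit. Compound 3 stands at > 100000 nM, which is such a limit.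

Compound 4 `Cc1cn([C@H]2C=C(F)[C@H](CO)O2)c(=O)nc1O` has not yet been measured. It relates to compound 3 by configuration alone: the two compounds have the same atoms and bonds and differ only in configuration as drawn: 1 of 2 stereo elements differ; a stereocentre at a saturated ring carbon is drawn S in compound 3 and R in compound 4. No atoms leave or enter.

Among the compounds with values here, the measured compounds provide no numerical step from which to size a change of configuration, so the expectation is tentative. In this assay, no step beyond the scatter is expected, and no direction is favoured. The expected step, a number no higher from compound 3 to compound 4 (the limit leaves the size open), is an estimate only. Compound 4 is expected at about 100000 nM, with an estimated range of 30000 nM to 300000 nM. A report as a limit, rather than a number, is the most likely outcome.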

Compound 4, half-maximal inhibitory concentration: > 100000 nM
Compound 4 gave a limit, no number (the forecaster's own chance of this, stated with the estimate: 85%); the middle value sits exactly at the limit.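

In this assay compound 3 gives > 100000 nM, a limit. Compound 4 gives > 100000 nM, also a limit, so no step can be read between compound 3 and compound 4. Left open is whether this stereocentre affects activity in this assay at all, and how any of the compounds shown rank: the limit of > 100000 nM in this assay, at which 4 of the 4 values shown sit.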